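A few compounds are considered here, and "the series" means these few. Any claim that something is new, unique, unknown or untested is made for them only; others in the source may bear on it.

Among the measured compounds shown here, in a functional assay on HL-60 cells (Homo sapiens) for cytotoxicity, read by luminescence and CellTiter-Glo, with a stated time of 3 days (a lower number here means a stronger inhibitor, a higher number a weaker inhibitor), compound 2 `O=C(Nc1cc(C(F)(F)F)cc(C(F)(F)F)c1)c1ccc(-c2ccccc2)cc1O` gives 1140 nM, the highest number of the three measured so far. Compound 1 `O=C(Nc1cc(C(F)(F)F)cc(C(F)(F)F)c1)c1cc(Br)c(-c2ccccc2)cc1O` gives 430 nM and compound 3 `O=C(Nc1ccc(OC(F)(F)F)c(Cl)c1)c1cc(Cl)ccc1O` gives 450 nM. Compound 4 `O=C(Nc1cc(C(F)(F)F)cc(C(F)(F)F)c1)c1ccc(Cl)cc1O` differs from compound 2 by one change: chloro in place of phenyl on an aromatic carbon. For the measured compounds named here, the only measured step, a 2.7-fold higher number from compound 1 to compound 2 (0.42 log units; beyond the scatter), is modest and concerns a bromo, not the phenyl, so it bears on this change only loosely. Compound 3 also carries a chloro and reaches 450 nM, though it differs from compound 4 in more than one place. A modest move to a lower number in this assay is therefore expected. The expected step is a 2.1-fold lower number from compound 2 to compound 4 (0.32 log units; beyond the scatter). Compound 4 is estimated at 550 nM, with an expected range of 220 nM to 1300 nM.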

Compound 4, half-maximal inhibitory concentration: 200 nM
For compound 4 the middle estimate is 2.8-fold (0.44 log units) above the measured one, and the stated range ends above it.
By their numbers in this assay, from the lowest: compound 4; then compounds 1 and 3 (each within the scatter of the next); then compound 2.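

In this assay the step of a 5.7-fold lower number from compound 2 to compound 4 (0.76 log units; beyond the scatter) shows that the phenyl is not needed for a lower number at this carbon, meta to a hydroxy group and para to a large group. The earlier step concerned a bromo with the phenyl kept in place, so it could not show that a single chloro, with no ring, outperforms the phenyl here. No evidence on the origin of this step is at hand.

Still open, on these data alone, is how a methoxy, an amine or a carboxylic acid would read on this same carbon of the shared core.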